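Varying the Amine on a Fused Bicyclic Core

The compounds below may be only part of what the source reports. "The series", "measured", "known", "first", "only" and "open" are said of these compounds alone.

Measured so far:
Compound 1, `O=C(CCc1ccc(C(F)(F)F)cc1)Nc1ccc2nc(N3CCCCC3)ccc2c1`, in an assay on isolated protein for displacement of a labelled ligand from melanin-concentrating hormone receptor 1 (Homo sapiens); on this read-out higher numbers stand for weaker inhibition and lower numbers for stronger inhibition: 12 nM
Compound 2, `CC(C)N(C)c1ccc2cc(NC(=O)CCc3ccc(C(F)(F)F)cc3)ccc2n1`, in this assay: 2 nM
Compound 3, `O=C(CCc1ccc(C(F)(F)F)cc1)Nc1ccc2nc(N3CCC(c4ccccc4)C3)ccc2c1`, in this assay: 25 nM

Compound 2 gives the lowest number of the three. Its nearest neighbour is compound 1, with a 6.0-fold lower number from compound 1 to compound 2 (0.78 log units; beyond the scatter), and compound 3 stands furthest from it, with a 13-fold higher number from compound 2 to compound 3 (1.10 log units; beyond the scatter). The piece now follows the step to compound 4, `CCCN(CCC)c1ccc2cc(NC(=O)CCc3ccc(C(F)(F)F)cc3)ccc2n1`, which is not yet measured. The change is dipropylamino in place of isopropyl(methyl)amino on an aromatic carbon.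

Going by the values given here, two measured steps bear on this. The step of a 6.0-fold lower number from compound 1 to compound 2 (0.78 log units; beyond the scatter) shows that a small acyclic amine at this position gives a lower number than a ring. The step of a 13-fold higher number from compound 2 to compound 3 (1.10 log units; beyond the scatter) shows that a bulkier ring gives a markedly higher number. Dipropylamino keeps the acyclic shape of compound 2 but carries more carbon, so a modest rise in the number is expected, short of the size seen with compound 3. Compound 4 is expected to reach 5 nM, within 1.5 nM to 15 nM, corresponding to an expected step of a 2.5-fold higher number from compound 2 to compound 4 (0.40 log units; beyond the scatter).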

Compound 4, half-maximal inhibitory concentration: 490 nM
The estimate for compound 4 lay 98-fold (1.99 log units) below the measured number, and the stated range ends below it.
By their numbers in this assay, from the lowest: compound 2; then compound 1; then compound 3; then compound 4.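

In this assay, the change to dipropylamino (a 250-fold higher number from compound 2 to compound 4 (2.39 log units; beyond the scatter)) shows that keeping the amine free of a ring does not by itself keep the number low at this position: the two acyclic amines now give the lowest and the highest of the four numbers. Compound 4 also lies above both ring-bearing compounds (a 41-fold higher number from compound 1 to compound 4 (1.61 log units; beyond the scatter); a 20-fold higher number from compound 3 to compound 4 (1.29 log units; beyond the scatter)), so the earlier ordering of the acyclic amine ahead of the rings holds for compound 2 only, and compound 4 goes against it. Nothing available explains this rise.

The compounds shown leave open how the number changes between these two acyclic amines. Diethylamino or methyl(propyl)amino at this position would show whether the rise is gradual or abrupt, and whether it takes both propyl chains.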